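Three measured compounds and one awaiting measurement

The source may hold more compounds than are shown below. What is called first, only, known or untested is meant among the compounds shown, and "the series" means these compounds.

Compound 1 `COc1ccc(C(=O)/C=C/c2ccc3c(ccc[n+]3[O-])c2)cc1`: 4.3 ug/mL
Compound 2 `COc1ccc(C(=O)/C=C/c2ccc3ncccc3c2)cc1`: 22.5 ug/mL
Compound 3 `O=C(/C=C/c1ccc2c(ccc[n+]2[O-])c1)c1ccc(Cl)cc1`: 4.9 ug/mL

In a functional assay on UACC-62 cells (Homo sapiens) for antiproliferative activity, read by sulforhodamine B assay, with a stated time of 48 h (a higher number here means a weaker inhibitor, a lower number a stronger inhibitor), compound 1 gives 4.3 ug/mL, while compound 3 gives 4.9 ug/mL. The step between them is a 1.1-fold higher number from compound 1 to compound 3 (0.06 log units; within the scatter), made by the change (chloro in place of methoxy on an aromatic carbon). Compound 2 has a different core, and that difference between the two cores is not broken down here; in this assay compound 2 gives 22.5 ug/mL, the highest of the three numbers. Compound 4 `O=C(/C=C/c1ccc2ncccc2c1)c1ccc(Cl)cc1` has not yet been measured. It differs from compound 2 by chloro in place of methoxy on an aromatic carbon, the same change as that made from compound 1 to compound 3. The step expected from compound 2 to compound 4 is a 1.1-fold higher number from compound 2 to compound 4 (0.05 log units; within the scatter), set beside the measured 1.1-fold higher number from compound 1 to compound 3 (0.06 log units; within the scatter), because a 1.1-fold higher number from compound 1 to compound 3 (0.06 log units; within the scatter) stays within the scatter. Compound 4 is therefore expected to give 25 ug/mL, most likely between 12 ug/mL and 50 ug/mL.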

Compound 4, half-maximal inhibitory concentration: "not active" (no number reported)
Nothing numeric was reported for compound 4, so the estimate cannot be set against anything.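

For the compounds shown here, compound 4 is reported as "not active" in this assay with no number, so no step from compound 2 to compound 4 can be read. The compounds shown leave open how chloro in place of methoxy acts on the core of compound 2. Nothing shown accounts for this result.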